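This account rests on a few compounds, and the source may have more. Where it says the series, first, only, none or still open, it means among the compounds named here.

Three compounds share one core and differ only in the group on the carbonyl carbon. In a functional assay on MIA PaCa-2 cells (Homo sapiens) for inhibition, read by MTT assay, with a stated time of 7 days (on this read-out higher numbers stand for weaker inhibition and lower numbers for stronger inhibition), compound 1 `CCN(CC)S(=O)(=O)c1ccc(S(=O)(=O)N2CCC[C@@H](C(=O)N3CCS(=O)(=O)CC3)C2)cc1` gives 900 nM, compound 2 `CCN(CC)S(=O)(=O)c1ccc(S(=O)(=O)N2CCC[C@@H](C(=O)N3CCOCC3)C2)cc1` gives 350 nM, and compound 3 `CCN(CC)S(=O)(=O)c1ccc(S(=O)(=O)N2CCC[C@@H](C(=O)N[C@@H]3CCOC3)C2)cc1` gives 750 nM. Compound 3 stands second highest of the three numbers: it sits close to compound 1, within the scatter, as a 1.2-fold lower number from compound 1 to compound 3 (0.08 log units; within the scatter) shows, while compound 2 lies beyond the scatter below it, as a 2.1-fold higher number from compound 2 to compound 3 (0.33 log units; beyond the scatter) shows. The remaining step is a 2.6-fold lower number from compound 1 to compound 2 (0.41 log units; beyond the scatter).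

Compound 4 `CCN(CC)S(=O)(=O)c1ccc(S(=O)(=O)N2CCC[C@@H](C(=O)N3CCC(OC)CC3)C2)cc1` has not yet been measured in this assay. It differs from compound 3 in one place: 4-methoxypiperidin-1-yl in place of (oxolan-3-yl)amino on a carbonyl carbon. The step that bears most on this change is a 2.1-fold higher number from compound 2 to compound 3 (0.33 log units; beyond the scatter), in which morpholin-4-yl, a six-membered non-aromatic ring without a hydrogen-bond donor, gave way to (oxolan-3-yl)amino; the change to compound 4 runs in the opposite direction, bringing back a six-membered non-aromatic ring with no hydrogen-bond donor. On that ground a modest downward step is expected, a 1.9-fold lower number from compound 3 to compound 4 (0.27 log units; within the scatter). Compound 4 is therefore estimated to give 400 nM in this assay, within a range from 150 nM to 1100 nM.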

Compound 4, half-maximal inhibitory concentration: 140 nM
The estimate for compound 4 lay 2.9-fold (0.46 log units) above the measured number, and the stated range ends above it.
By their numbers in this assay, from the lowest: compound 4; then compound 2; then compounds 3 and 1 (each within the scatter of the next).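

In this assay, among the compounds shown here, the group on the carbonyl carbon proves able to reach lower numbers than the earlier compounds showed: 4-methoxypiperidin-1-yl gives the lowest number of the four, with every step to it beyond the scatter (a 5.4-fold lower number from compound 3 to compound 4 (0.73 log units; beyond the scatter); a 2.5-fold lower number from compound 2 to compound 4 (0.40 log units; beyond the scatter); a 6.4-fold lower number from compound 1 to compound 4 (0.81 log units; beyond the scatter)). The earlier compounds shown here had marked morpholin-4-yl as the best group at this position, and compound 4 shows that this was not the limit, even though the entering group is larger than (oxolan-3-yl)amino, with 8 heavy atoms against 6. A six-membered non-aromatic ring alone does not give a low number, since compound 1 carries one and stands at the high end of the series, so the result depends on which such ring is present.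

Nothing measured here explains these differences. From the compounds shown here alone, it remains open whether the methoxy group matters or the piperidine ring alone is enough, which a plain piperidin-1-yl, a 4-hydroxypiperidin-1-yl or a 4-ethoxypiperidin-1-yl on the same carbonyl carbon would help to settle.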